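The source may report more compounds than this note shows. Statements on the series, on what has been measured and on what is new or still open speak of the compounds shown alone.

Measured so far in a functional assay on MCF7 cells (Homo sapiens) for inhibition, read by MTT assay, with a stated time of 24 h; a lower number here means a stronger inhibitor of growth, a higher number a weaker inhibitor of growth:
compound 1 `Cn1cc(-c2nc3ccccc3n2C(=O)c2ccccc2)c2ccccc21` gives 43700 nM
compound 2 `COc1ccc2c(c1)c(-c1nc3ccccc3n1C(=O)c1ccccc1)cn2C` gives 38400 nM
compound 3 `COc1ccc2c(c1)c(-c1nc3ccccc3n1C(=O)c1ccc(OC)c(OC)c1)cn2C` gives 6300 nM

Compound 2 stands at the high end of the three numbers in this assay and cannot be told apart from compound 1. Only compound 3 lies clearly away from it.

Next is compound 4 `Cn1cc(-c2nc3ccccc3n2C(=O)c2ccccc2)c2cc(Br)ccc21` with the change bromo in place of methoxy on an aromatic carbon on an aromatic carbon of a six-membered aromatic ring of carbon only. Everything else matches compound 2, including the phenyl on the carbonyl carbon.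

The step that bears most directly on this carbon is a 1.1-fold lower number from compound 1 to compound 2 (0.06 log units; within the scatter) and it shows no measurable response to swapping hydrogen for methoxy. The other measured step, a 6.1-fold lower number from compound 2 to compound 3 (0.78 log units; beyond the scatter) in this series, is larger but sits on the carbonyl side, so it says little about this carbon. Among the measured compounds shown here, no bromo compound has been measured yet, so this rests on a single comparison.

No step beyond the scatter is expected in this assay and no direction is favoured. The expected size is a 1.1-fold lower number from compound 2 to compound 4 (0.03 log units; within the scatter) for this change. Compound 4 is estimated at 36000 nM with an expected range of 15000 nM to 85000 nM for now.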

Compound 4, concentration for 50% growth inhibition: 50300 nM
For compound 4 the middle estimate is 1.4-fold (0.15 log units) below the measured one; low and high end bracket the measured number.
By their numbers in this assay, from the lowest: compound 3; then compounds 2, 1 and 4 (each within the scatter of the next).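

In this assay, bromo in place of methoxy gives a 1.3-fold higher number from compound 2 to compound 4 (0.12 log units; within the scatter), and bromo in place of hydrogen gives a 1.2-fold higher number from compound 1 to compound 4 (0.06 log units; within the scatter), so hydrogen, methoxy and bromo on this aromatic carbon all lie within the scatter of one another. The earlier compounds shown here tested only the swap of hydrogen for methoxy at this carbon; with bromo as a second group, the flat reading now covers two different replacements of hydrogen, with the phenyl on the carbonyl carbon kept throughout. No measured evidence is available to explain why these numbers stay together.

From the compounds shown here alone, whether this carbon stays as unresponsive with an amine, a carboxylic acid or a longer chain such as butoxy remains open, since three closely spaced values cover only a narrow set of groups. Among the compounds shown here, also open is whether bromo at this carbon would match methoxy when the carbonyl carbon carries 3,4-dimethoxyphenyl in place of phenyl, the one change with a step beyond the scatter.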